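A 1-methyl-1H-tetrazol-5-yl group on the sulfur of compound 3

The compounds below may be only part of what the source reports. "The series", "measured", "known", "first", "only" and "open" are said of these compounds alone.

Measured so far in a functional assay on HepG2 cells (Homo sapiens) for antiproliferative activity, read by MTT assay, with a stated time of 48 h; a higher number here means a weaker inhibitor, a lower number a stronger inhibitor

Compound 1 `COc1ccc(CN(C(=O)Cn2cc(COc3cc(=O)oc4ccccc34)nn2)c2cc(OC)c(OC)c(OC)c2)cc1` gives 6250 nM
Compound 2 `COc1ccc(CN(C(=O)Cn2cc(CSC3=NCCS3)nn2)c2cc(OC)c(OC)c(OC)c2)cc1` gives 25000 nM
Compound 3 `COc1ccc(CN(C(=O)Cn2cc(CSc3nc4ccccc4o3)nn2)c2cc(OC)c(OC)c(OC)c2)cc1` gives 15600 nM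

Compound 3 cannot be told apart from compound 2, but its number lies above that of compound 1, with a 2.5-fold higher number from compound 1 to compound 3 (0.40 log units; beyond the scatter) as the gap. Compound 4 `COc1ccc(CN(C(=O)Cn2cc(CSc3nnnn3C)nn2)c2cc(OC)c(OC)c(OC)c2)cc1` carries 1-methyl-1H-tetrazol-5-yl in place of 1,3-benzoxazol-2-yl on a sulfur. Among the measured compounds shown here, the only other swap on this sulfur, a 1.6-fold lower number from compound 2 to compound 3 (0.20 log units; within the scatter), stayed small. The remaining step, a 4.0-fold higher number from compound 1 to compound 2 (0.60 log units; beyond the scatter), is modest and also replaces the sulfur. No step beyond the scatter is therefore expected in this assay. For compound 4, the estimated step is a 1.3-fold higher number from compound 3 to compound 4 (0.11 log units; within the scatter). Compound 4 is estimated at 20000 nM, with an expected range from 8000 nM to 50000 nM.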

Compound 4, half-maximal inhibitory concentration: 28300 nM
Beside the measured number, compound 4's estimate is 1.4-fold (0.15 log units) below it; low and high end bracket the measured number.
By their numbers in this assay, from the lowest: compound 1; then compounds 3, 2 and 4 (each within the scatter of the next).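

In this assay, trading 1,3-benzoxazol-2-yl for the smaller 1-methyl-1H-tetrazol-5-yl on the sulfur, which drops the six-membered carbon ring, gives a 1.8-fold higher number from compound 3 to compound 4 (0.26 log units; within the scatter) and so shows no clear effect. A second comparison on this sulfur, a 1.1-fold higher number from compound 2 to compound 4 (0.05 log units; within the scatter), agrees, while the step to the group of compound 1, a 4.5-fold higher number from compound 1 to compound 4 (0.66 log units; beyond the scatter), remains the only one beyond the scatter here. No available measurement explains why these groups on the sulfur read alike.

Open, going by these compounds, is whether a much smaller group, such as a plain methyl, would read the same on this sulfur. Also open, on these data alone, is whether an amine or a carboxylic acid there would change the number.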